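The source may report more compounds than this note shows. Statements on the series, on what has been measured and on what is new or still open speak of the compounds shown alone.

Working notes on the series. Two compounds have been run in a functional assay on KG-1 cells (Homo sapiens) for cytotoxicity, read by luminescence and CellTiter-Glo, with a stated time of 3 days; a higher number here means a weaker inhibitor, a lower number a stronger inhibitor. Compound 1 is `N#Cc1ccc(NC(=O)c2ccc(-c3cccnc3)cc2O)cc1`; in this assay compound 1 gives 7940 nM. Compound 2 is `N#Cc1ccc(NC(=O)c2cc(-c3cccnc3)ccc2O)cc1`; in this assay compound 2 gives 8330 nM. The two values lie within the usual scatter of each other, so compound 2 and compound 1 cannot be told apart on these numbers, and both sit at the weak end of what this assay resolves.

Compound 3 is `N#Cc1ccc(NC(=O)c2cc(C(F)(F)F)ccc2O)cc1`, not yet measured. It differs from compound 2 in one place: trifluoromethyl in place of pyridin-3-yl on an aromatic carbon. For the measured compounds named here, two measured points give no step of this kind to lean on. With the pyridin-3-yl gone and a trifluoromethyl in its place, the working expectation is a small move toward a higher number, of a size that may not clear the scatter, expressed as a 1.4-fold higher number from compound 2 to compound 3 (0.16 log units; within the scatter). Accordingly compound 3 is expected to give about 12000 nM in this assay, with a range from 4000 nM to 40000 nM.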

Compound 3, half-maximal inhibitory concentration: 4810 nM
Beside the measured number, compound 3's estimate is 2.5-fold (0.40 log units) above it; the range from low to high includes it.
By their numbers in this assay, from the lowest: compounds 3, 1 and 2 (each within the scatter of the next).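

In this assay, replacing pyridin-3-yl with trifluoromethyl on the aromatic carbon para to a hydroxy group and meta to a large group gives a 1.7-fold lower number from compound 2 to compound 3 (0.24 log units; within the scatter), so this replacement does not separate the two compounds. This position therefore accepts a group with no ring and no hydrogen-bond acceptor in place of a six-membered aromatic ring carrying a hydrogen-bond acceptor, without a resolved loss or gain in this cytotoxicity read-out; neither that ring nor its ring nitrogen is needed to keep the number at this level. Nothing available on these compounds accounts for this outcome.

As far as these compounds go, it remains open whether a different kind of group at this position, such as an amine, a carboxylic acid or a longer alkyl chain, would move the number beyond the scatter. From the compounds shown here alone, it is also open whether trifluoromethyl would give a similar result on the carbon that carries pyridin-3-yl in compound 1, and whether any substituent on this core can reach a number well away from the weak end of what the assay resolves.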